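The source may report more compounds than this note shows. Statements on the series, on what has been measured and on what is new or still open speak of the compounds shown alone.

In a functional assay on PC-3 cells (Homo sapiens) for inhibition, read by colorimetric assay and MTT assay, with a stated time of 72 h (a higher number here means a weaker inhibitor, a lower number a stronger inhibitor), compound 1 `Cn1c2cnc1OCCCCCCCCOc1cc(F)ccc1-2` gives 46000 nM and compound 2 `CCCCOc1ncc(-c2ccccc2OC)n1C` gives 71000 nM, so these two values lie within the usual scatter of each other. Compound 3 `C#CCCCCOc1ncc(-c2ccccc2OC)n1C` has ethynyl in place of hydrogen on a saturated chain carbon, four bonds along the chain from an oxygen on an aromatic ring. Among the compounds with values here, no measured pair shows what such a change does, so no shift beyond the scatter is expected in either direction. The expected step, a 1.2-fold lower number from compound 2 to compound 3 (0.07 log units; within the scatter), stays within the scatter. For compound 3 the estimated value is 60000 nM, with an expected range of 25000 nM to 130000 nM.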

Compound 3, half-maximal inhibitory concentration: 21000 nM
Compound 3: middle estimate off by 2.9-fold (0.46 log units), on the high side; measured number below the stated range.
By their numbers in this assay, from the lowest: compound 3; then compounds 1 and 2 (each within the scatter of the next).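

In this assay, ethynyl in place of hydrogen on a saturated chain carbon, four bonds along the chain from an oxygen on an aromatic ring, gives a 3.4-fold lower number from compound 2 to compound 3 (0.53 log units; beyond the scatter). This shows that a change at the far end of this chain can move the number beyond the scatter, though only modestly, and towards a stronger inhibitor. No available measurement explains the shift. The compounds shown leave open whether the triple bond or the added chain length goes with this step. A plain hexyl chain at this place would separate the two.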